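The compounds below may be only part of what the source reports. "The series", "measured", "known", "first", "only" and "open" are said of these compounds alone.

Working notes on the series. Among the compounds with values here, in a functional assay on C8166 cells (Homo sapiens) for cytotoxicity, read by MTT assay, with a stated time of 72 h (a higher number here means that more compound is tolerated, a lower number that less compound is tolerated), compound 1 `Cc1ccc(S(=O)(=O)N2CC3(C[C@H]2C(=O)N/N=C/c2ccccc2[N+](=O)[O-])SCCS3)cc1` gives 65000 nM, the only true number so far. Compound 2 `C/C(=N\NC(=O)Cn1c(=O)c(C)nc2ccccc21)c1ccccc1Cl` reports > 543000 nM, which is a limit and not a number. Compound 3 `COc1ccc(/C=C/C(=O)N2C[C@@H](NC(=O)c3cccnc3)C[C@H]2C(=O)NO)cc1OC` reports > 454000 nM, also a limit and not a number. Within the data shown here, compound 1 is therefore the only compound with a measured position.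

Compound 4 `COc1ccccc1/C=N/NC(=O)[C@@H]1CC2(CN1S(=O)(=O)c1ccc(C)cc1)SCCS2` keeps the core of compound 1 and changes one group: methoxy in place of nitro on an aromatic carbon. This is methoxy in place of nitro on an aromatic carbon, ortho to a large group, so 2-nitrophenyl becomes 2-methoxyphenyl. Among the measured compounds shown here, no measured pair isolates this change, and the only numerical anchor is compound 1 at 65000 nM. A moderate step in this assay is expected, towards more compound tolerated, with some chance that only a limit is reported. The expected change is a 1.8-fold higher number from compound 1 to compound 4 (0.27 log units; within the scatter). For compound 4 the estimated value is 120000 nM, with an expected range of 35000 nM to 420000 nM.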

Compound 4, half-maximal cytotoxic concentration: 388000 nM
Beside the measured number, compound 4's estimate is 3.2-fold (0.51 log units) below it; low and high end bracket the measured number.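

In this assay, within the data shown here, the change from 2-nitrophenyl to 2-methoxyphenyl on the core of compound 1 gives the first pair that differs in one place, and the number moves towards more compound tolerated (a 6.0-fold higher number from compound 1 to compound 4 (0.78 log units; beyond the scatter)). Substitution on this aromatic carbon, ortho to a large group, therefore affects this read-out by more than the usual scatter, which the earlier compounds, with no such pair among them, could not show. Nothing measured here bears on why the number moves.

This single pair does not separate the loss of nitro from the gain of methoxy. Hydrogen, an amine or a carboxylic acid on the same aromatic carbon would show whether the number follows the group that enters or simply the absence of nitro.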